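The source may hold more compounds than are shown below. What is called first, only, known or untested is meant among the compounds shown, and "the series" means these compounds.

Measured so far in a functional assay on the whole organism with Rattus norvegicus as the target; on this read-out lower numbers stand for an effect already at smaller amounts and higher numbers for an effect only at larger amounts of compound:
compound 1 `C[C@@H]1CC/C(=N\Nc2ccccc2)c2ncc(C(=O)O)c(=O)n21`: 54.8 umol/kg
compound 2 `CC1CCC(/C=N/c2ccccc2C(=O)O)=C2NC=C(C(=O)O)C(=O)N21`: 1.11 umol/kg
compound 3 `CC1CCC(/C=N/c2ccccc2F)=C2NC=C(C(=O)O)C(=O)N21`: 14.5 umol/kg

Compound 3 stands second highest of the three numbers in this assay; compound 1 gives a higher number and compound 2 a lower one, both gaps beyond the scatter. Compound 4 `CC1CCC(/C=N/c2ccc(O)cc2)=C2NC=C(C(=O)O)C(=O)N21` differs from compound 3 by 4-hydroxyphenyl in place of 2-fluorophenyl on a double-bonded nitrogen. Going by the values given here, the only measured step that bears on this is a 13-fold higher number from compound 2 to compound 3 (1.12 log units; beyond the scatter), where a group carrying a hydrogen-bond donor and acceptor gave way to fluoro and the number rose sharply. The change to 4-hydroxyphenyl brings back one donor and one acceptor, so a lower number is expected, though a smaller move than that step, since hydroxy is not carboxy. Compound 4 is expected at 7 umol/kg (range 2 umol/kg to 25 umol/kg), an expected step of a 2.1-fold lower number from compound 3 to compound 4 (0.32 log units; beyond the scatter).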

Compound 4, dose for 50% inhibition: 1.2 umol/kg
Compound 4: the middle estimate sits 5.8-fold (0.77 log units) above what was measured; the measured number lies below the stated range.
By their numbers in this assay, from the lowest: compounds 2 and 4 (each within the scatter of the next); then compound 3; then compound 1.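

On a double-bonded nitrogen in this assay, the aryl group can move the number widely even without a carboxy group: 4-hydroxyphenyl in place of 2-fluorophenyl gives a 12-fold lower number from compound 3 to compound 4 (1.08 log units; beyond the scatter) at the same heavy-atom count. Compound 2 at 1.11 umol/kg and compound 4 at 1.2 umol/kg lie within the scatter of each other, so a low number here does not depend on carboxy on the aromatic ring. Nothing measured accounts for the step.

The step changes the substituent and its ring position together, and the two effects remain unseparated. How an amine or a methoxy group on that phenyl ring would read is open.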